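Acetamido for hydroxymethyl on the core of compound 1

The compounds below may be only part of what the source reports. "The series", "measured", "known", "first", "only" and "open" are said of these compounds alone.

Measured so far:
compound 1, `CCCCN(c1nc2c(CO)cccc2o1)[C@H](C)c1ccc(-c2ccccc2-c2nnn[nH]2)cc1`, 24 nM
compound 2, `Cc1ccc(-c2nc(=O)o[nH]2)c(-c2ccc([C@@H](C)N(CC3CC3)c3nc4c(C(=O)O)cccc4o3)cc2)c1`, 3.2 nM

In a functional assay on CAL1 cells for inhibition of chemerin-like receptor 1 (Homo sapiens), with a stated time of 45 min (a lower number here means a stronger inhibitor, a higher number a weaker inhibitor), compound 1 gives 24 nM and stands as the higher of the two numbers measured. Compound 2 gives 3.2 nM in this assay, a lower number than compound 1 by a gap that lies beyond the usual scatter. Compound 2 differs from compound 1 in several places at once, so its values say nothing about any single change.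

Compound 3, `CCCCN(c1nc2c(NC(C)=O)cccc2o1)[C@H](C)c1ccc(-c2ccccc2-c2nnn[nH]2)cc1`, has not been measured. Its change from compound 1 is acetamido in place of hydroxymethyl on an aromatic carbon, with the acetamido sitting on the aromatic carbon of the six-membered ring of the fused system where the hydroxymethyl stood. Within the data shown here, no measured pair isolates this kind of exchange, so no direction is backed by data. Both the leaving and the entering group carry one hydrogen-bond donor and one acceptor, and the step is expected to be small: a 1.3-fold higher number from compound 1 to compound 3 (0.12 log units; within the scatter) is estimated to fall within or only just beyond the scatter, if anything toward a weaker inhibitor. Compound 3 is therefore expected to give about 32 nM in this assay, in the range 10 nM to 100 nM.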

Compound 3, half-maximal inhibitory concentration: 22 nM
Compound 3: middle estimate off by 1.5-fold (0.16 log units), on the high side; the measured number falls inside the stated range.
By their numbers in this assay, from the lowest: compound 2; then compounds 3 and 1 (each within the scatter of the next).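

In this assay the exchange of hydroxymethyl for acetamido gives a 1.1-fold lower number from compound 1 to compound 3 (0.04 log units; within the scatter) and so provides the only single-place comparison among the compounds shown: at this aromatic carbon, ortho to a fused ring and meta to a fused ring, the two groups cannot be told apart in this read-out. The entering group has 4 heavy atoms against 2 for the leaving group and adds a double bond outside aromatic rings, while the counts of hydrogen-bond donors and acceptors stay the same, so this one pair shows that such a change need not move the number beyond the scatter. No measurement at hand offers an explanation for this match between the two groups.

Going by these compounds, whether the same position also accepts a primary amine, a methoxy group, a longer amide chain or plain hydrogen remains open, and a group lacking the hydrogen-bond donor would be the more searching test of what this place requires. Compound 2 differs from compound 1 and compound 3 in several places at once, so the share of its carboxylic acid in its number cannot be read from these compounds.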